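Indole sulfonyl acrylonitriles: restoring the aryl group

The source may report more compounds than this note shows. Statements on the series, on what has been measured and on what is new or still open speak of the compounds shown alone.

Within the data shown here, compound 3 `N#C/C(=C\c1c[nH]c2ccccc12)S(=O)(=O)c1ccccc1` is the one member of the series that returns only a limit in a functional assay on MT4 cells (Homo sapiens) for antiproliferative activity, read by MTT assay, with a stated time of 96 h; a lower number here means that less compound is needed, a higher number that more compound is needed for the effect: > 100000 nM. That value sits at the edge of the scale, as noted in the limit of > 100000 nM in this assay, at which 1 of the 3 values shown sits, so compound 3 stands at the bottom of the measured set, with no number of its own. Compound 1 `COc1ccc(-c2[nH]c3ccccc3c2/C=C(\C#N)S(=O)(=O)c2ccccc2)cc1` gives 200 nM. Compound 2 `O=C(/C(=C\c1c(-c2ccccc2)[nH]c2ccccc12)S(=O)(=O)c1ccccc1)c1ccccc1` gives 3000 nM.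

Compound 4 `N#C/C(=C\c1c(-c2ccccc2)[nH]c2ccccc12)S(=O)(=O)c1ccccc1` differs from compound 3 by phenyl in place of hydrogen on an aromatic carbon. Among the measured compounds shown here, the one measured step that bears on this change runs in the opposite direction: an at least 500-fold higher number from compound 1 to compound 3 (2.69 log units; beyond the scatter). Compound 4 puts an aryl group back at the position where compound 1 carries 4-methoxyphenyl, while compound 2 already carries the same phenyl at that place together with a benzoyl group instead of the nitrile. A large drop in the number is therefore expected, landing between the values of compound 1 and compound 2.

For compound 4 the expected value is 600 nM, with a range from 150 nM to 3000 nM. The step from compound 3 to compound 4 is thus estimated as an at least 160-fold lower number from compound 3 to compound 4 (2.22 log units; beyond the scatter).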

Compound 4, half-maximal effective concentration: 400 nM
The estimate for compound 4 lay 1.5-fold (0.18 log units) above the measured number; low and high end bracket the measured number.
By their numbers in this assay, from the lowest: compounds 1 and 4 (each within the scatter of the next); then compound 2. At a limit, above all of these: compound 3.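

Phenyl in place of hydrogen on this aromatic carbon, with nothing further on that ring, is enough to bring the nitrile compounds into a measurable range in this assay (an at least 250-fold lower number from compound 3 to compound 4 (2.39 log units; beyond the scatter)), and the methoxy of compound 1 makes no difference that can be told from the scatter (a 2.0-fold higher number from compound 1 to compound 4 (0.30 log units; within the scatter)). With phenyl held at that place, nitrile and benzoyl can now be compared directly, and the nitrile gives the lower number (a 7.5-fold lower number from compound 2 to compound 4 (0.88 log units; beyond the scatter)). The first of these steps is a bound only, since compound 3 stands at a limit of the assay: the limit of > 100000 nM in this assay, at which 1 of the 4 values shown sits.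

Open, as far as these compounds go, is whether a group other than an aryl ring at this carbon, such as an amine or a short alkyl chain, would also give a low number. Also open, from the compounds shown here alone, is what a carboxylic acid on the phenyl would do.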